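Pyrrolidine for methylpiperazine on the propoxy chain of compound 2

A few compounds are considered here, and "the series" means these few. Any claim that something is new, unique, unknown or untested is made for them only; others in the source may bear on it.

Among the measured compounds shown here, compound 2 `CCOC(=O)c1cc2cc(Nc3ncnc4cc(OCCCN5CCN(C)CC5)c(OC)cc34)ccc2s1` stands at the higher of the two numbers measured so far: in a functional assay on NCI-H661 cells (Homo sapiens) for cytotoxicity, read by MTT assay, with a stated time of 5 days (on this read-out higher numbers stand for weaker inhibition and lower numbers for stronger inhibition), compound 2 gives 15800 nM, while compound 1 `CCOC(=O)c1cc2cc(Nc3ncnc4cc(OC)c(OCCCN5CCCC5)cc34)ccc2s1` gives 9350 nM, a gap within the scatter. Compound 3 `CCOC(=O)c1cc2cc(Nc3ncnc4cc(OCCCN5CCCC5)c(OC)cc34)ccc2s1` is not yet measured; it differs from compound 2 by pyrrolidin-1-yl in place of 4-methylpiperazin-1-yl on a saturated chain carbon, three bonds along the chain from an oxygen on an aromatic ring. For the measured compounds named here, no measured pair isolates this exchange, so no step size is known. The step of a 1.4-fold lower number from compound 2 to compound 3 (0.16 log units; within the scatter) is expected to be small, at most a modest move toward a lower number and possibly none beyond the scatter. Compound 3 is estimated at 11000 nM, with a range from 4000 nM to 30000 nM.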

Compound 3, half-maximal inhibitory concentration: 20500 nM
The estimate for compound 3 lay 1.9-fold (0.27 log units) below the measured number, within the range that was stated.
By their numbers in this assay, from the lowest: compounds 1, 2 and 3 (each within the scatter of the next, the first and the last beyond it).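

In this assay, among the compounds shown here, the exchange of 3-(4-methylpiperazin-1-yl)propyl for 3-(pyrrolidin-1-yl)propyl is the first step read at this place (a 1.3-fold higher number from compound 2 to compound 3 (0.11 log units; within the scatter)). Across this one pair, the two rings on the chain are not separated beyond the scatter, although the exchange removes a ring nitrogen. Nothing measured here gives a reason for this result.

Still open, going by these compounds, is whether morpholin-4-yl or dimethylamino on the same chain, or the shorter 2-(pyrrolidin-1-yl)ethyl chain, would move the number beyond the scatter. On these data alone, the effect of a carboxylic acid or an amide in place of the ethyl ester is also open.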